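Acyl chain in the series: 1-aminopropyl to 1-amino-2-methylpropyl

This account rests on a few compounds, and the source may have more. Where it says the series, first, only, none or still open, it means among the compounds named here.

Values so far in a functional assay on HCT-116 cells (Homo sapiens) for antiproliferative activity; on this read-out higher numbers stand for weaker inhibition and lower numbers for stronger inhibition
- compound 1 (`COCCC(=O)N1CCc2c(C)c3c(n2-c2ccc(C(N)=O)c(c2)N[C@@H](C)[C@H](C)C1)CC(C)(C)CC3=O`): 38 nM
- compound 2 (`CC[C@H](N)C(=O)N1CCc2c(C)c3c(n2-c2ccc(C(N)=O)c(c2)N[C@@H](C)[C@H](C)C1)CC(C)(C)CC3=O`): 33 nM

Within the data shown here, compound 2 at 33 nM lies within the scatter of compound 1, the only other measured compound. Compound 3 (`Cc1c2c(n3c1CCN(C(=O)[C@@H](N)C(C)C)C[C@@H](C)[C@H](C)Nc1cc-3ccc1C(N)=O)CC(C)(C)CC2=O`) keeps the shared core and changes only the acyl chain of compound 2. The difference is methyl in place of hydrogen on a saturated chain carbon bound to two saturated chain carbons, which turns 1-aminopropyl into 1-amino-2-methylpropyl.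

Among the measured compounds shown here, one measured step bears on this: a 1.2-fold lower number from compound 1 to compound 2 (0.06 log units; within the scatter) (1-aminopropyl in place of 2-methoxyethyl on a carbonyl carbon). It concerns the same acyl chain and stays within the scatter. For the measured compounds named here, it is a different change, however, and no measured compound carries the 1-amino-2-methylpropyl group, so the range has to stay wide. No direction can be read from one such step.

The step expected in this assay is small, estimated as a 1.1-fold higher number from compound 2 to compound 3 (0.03 log units; within the scatter) and not beyond the scatter. For compound 3 the expected value is 35 nM (estimated range 14 nM to 85 nM).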

Compound 3, half-maximal inhibitory concentration: 30 nM
Compound 3: the middle estimate sits 1.2-fold (0.07 log units) above what was measured, within the range that was stated.
By their numbers in this assay, from the lowest: compounds 3, 2 and 1 (each within the scatter of the next).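

In this assay, methyl in place of hydrogen on a saturated chain carbon bound to two saturated chain carbons, which turns 1-aminopropyl into 1-amino-2-methylpropyl, comes to a 1.1-fold lower number from compound 2 to compound 3 (0.04 log units; within the scatter), so this added methyl leaves no readable mark on the number. The comparison with the 2-methoxyethyl chain gives a 1.3-fold lower number from compound 1 to compound 3 (0.10 log units; within the scatter), which also stays inside the scatter, so all three acyl chains shown, 2-methoxyethyl, 1-aminopropyl and 1-amino-2-methylpropyl, cannot be told apart on this read-out, and none of the three compounds goes against that. No measurement at hand explains why these acyl chains read alike.

Open, as far as these compounds go, is whether a larger group such as tert-butyl or phenyl in place of the isopropyl end of the chain would still stay within the scatter, and whether an acyl chain without an amine, such as plain acetyl, would read the same as the amine-bearing chains. Also open, from the compounds shown here alone, is whether a carboxylic acid on the acyl chain, or a longer chain, would finally separate the compounds in this assay.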